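This account rests on a few compounds, and the source may have more. Where it says the series, first, only, none or still open, it means among the compounds named here.

Measured compounds:
Compound 1 `C=CCn1c(=O)/c(=C\c2cccc(F)c2)[nH]c(=O)/c1=C\c1ccccc1OC` gives 25600 nM in a functional assay on NCI-H1975 cells (Homo sapiens) for cytotoxicity, read by CCK-8 assay, with a stated time of 72 h; on this read-out lower numbers stand for stronger inhibition and higher numbers for weaker inhibition.
Compound 2 `C=CCn1c(=O)/c(=C\c2ccccc2Cl)[nH]c(=O)/c1=C\c1ccccc1OC` gives 9200 nM in this assay.
Compound 3 `C=CCn1c(=O)/c(=C\c2ccccc2C(F)(F)F)[nH]c(=O)/c1=C\c1ccccc1OC` gives 14500 nM in this assay.

Compound 3 stands second highest of the three numbers. Its nearest neighbour is compound 2, separated by a 1.6-fold higher number from compound 2 to compound 3 (0.20 log units; within the scatter), and its furthest is compound 1, separated by a 1.8-fold lower number from compound 1 to compound 3 (0.25 log units; within the scatter), both gaps falling within the scatter. Compound 4 `C=CCn1c(=O)/c(=C\c2cc(F)ccc2C)[nH]c(=O)/c1=C\c1ccccc1OC` has not yet been measured in this assay. It differs from compound 3 by 5-fluoro-2-methylphenyl in place of 2-(trifluoromethyl)phenyl on a double-bonded chain carbon bound to an aromatic carbon. Within the data shown here, the steps that bear on this change are those that exchange the aryl group on the same double-bonded chain carbon: a 2.8-fold lower number from compound 1 to compound 2 (0.44 log units; beyond the scatter), a 1.8-fold lower number from compound 1 to compound 3 (0.25 log units; within the scatter) and a 1.6-fold higher number from compound 2 to compound 3 (0.20 log units; within the scatter). Only the first of these exceeds the scatter, and all three measured compounds occupy a narrow band. The writer therefore expects for compound 4 a step of a 1.2-fold lower number from compound 3 to compound 4 (0.08 log units; within the scatter) in this assay, not beyond the scatter. The estimate for compound 4 in this assay is 12000 nM, with a range from 5000 nM to 30000 nM.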

Compound 4, half-maximal inhibitory concentration: 7300 nM
Estimate against measurement, compound 4: 1.6-fold (0.22 log units) above, and the stated range covers the measured number.
By their numbers in this assay, from the lowest: compounds 4, 2, 3 and 1 (each within the scatter of the next, the first and the last beyond it).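

In this assay, methyl in place of hydrogen on an aromatic carbon gives a 3.5-fold lower number from compound 1 to compound 4 (0.54 log units; beyond the scatter), so a second aryl group now stands clear of the 3-fluorophenyl of compound 1, as the 2-chlorophenyl of compound 2 did, while the 2-(trifluoromethyl)phenyl of compound 3 does not. The other two exchanges at this place, a 2.0-fold lower number from compound 3 to compound 4 (0.30 log units; within the scatter) and a 1.3-fold lower number from compound 2 to compound 4 (0.10 log units; within the scatter), stay within the scatter, so the 5-fluoro-2-methylphenyl group cannot be separated from either of those aryl groups. No measurement shown accounts for these differences.

The compounds shown leave open whether a plain 2-methylphenyl group, without the fluorine, would give a similar number. They also leave open how an amine or a carboxylic acid on this aryl group would read out.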